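A few compounds are considered here, and "the series" means these few. Any claim that something is new, unique, unknown or untested is made for them only; others in the source may bear on it.

Of the compounds shown here, three sharing one core have been measured in a functional assay on 1321-N1 cells for agonist activity at P2Y purinoceptor 4 (Homo sapiens), read by scintillation counting and inositol phosphate accumulation; a lower number here means that less compound is needed, a higher number that more compound is needed for the effect. Compound 1 `O=c1[nH]/c(=N\OCCCCc2ccccc2)ccn1[C@@H]1O[C@H](COP(=O)(O)OP(=O)(O)OP(=O)(O)O)[C@@H](O)[C@H]1O` gives 54 nM. Compound 2 `O=c1[nH]/c(=N\OCCCc2ccc([N+](=O)[O-])cc2)ccn1[C@@H]1O[C@H](COP(=O)(O)OP(=O)(O)OP(=O)(O)O)[C@@H](O)[C@H]1O` gives 84 nM. Compound 3 `O=c1[nH]/c(=N\OCCCc2cccnc2)ccn1[C@@H]1O[C@H](COP(=O)(O)OP(=O)(O)OP(=O)(O)O)[C@@H](O)[C@H]1O` gives 300 nM, the highest of the three numbers. Two steps lead to it: a 5.6-fold higher number from compound 1 to compound 3 (0.74 log units; beyond the scatter) and a 3.6-fold higher number from compound 2 to compound 3 (0.55 log units; beyond the scatter), whereas a 1.6-fold higher number from compound 1 to compound 2 (0.19 log units; within the scatter). Compound 4 `C#CCCCO/N=c1/ccn([C@@H]2O[C@H](COP(=O)(O)OP(=O)(O)OP(=O)(O)O)[C@@H](O)[C@H]2O)c(=O)[nH]1` has not yet been measured in this assay; it differs from compound 3 by ethynyl in place of pyridin-3-yl on a saturated chain carbon, three bonds along the chain from an oxygen. Among the measured compounds shown here, no measured step exchanges the ring for a short open chain, so only the two ring exchanges bear on the question, and each moved the number by a modest amount. Compound 4 is therefore expected to give 150 nM, in a range from 40 nM to 600 nM, which would be an expected step of a 2.0-fold lower number from compound 3 to compound 4 (0.30 log units; within the scatter).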

Compound 4, half-maximal effective concentration: 410 nM
Beside the measured number, compound 4's estimate is 2.7-fold (0.44 log units) below it; the measured number falls inside the stated range.
By their numbers in this assay, from the lowest: compounds 1 and 2 (each within the scatter of the next); then compounds 3 and 4 (each within the scatter of the next).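

Ethynyl, with no ring and far fewer heavy atoms, matches pyridin-3-yl at this place, with a 1.4-fold higher number from compound 3 to compound 4 (0.14 log units; within the scatter), so a ring is not needed here to hold the number at the level of compound 3. The larger steps, a 4.9-fold higher number from compound 2 to compound 4 (0.69 log units; beyond the scatter) and a 7.6-fold higher number from compound 1 to compound 4 (0.88 log units; beyond the scatter), show that not every group at this place gives the same result, and having a ring does not by itself decide the outcome, since compound 3 has one yet stands with compound 4. Nothing measured here explains these differences.

Still open, as far as these compounds go, is whether a longer chain ending in ethynyl would bring the number closer to that of compound 1. Also open, from the compounds shown here alone, is how an amine or a carboxylic acid would behave at this place.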